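Swapping the aryl ether for a thioether on the core

The source may report more compounds than this note shows. Statements on the series, on what has been measured and on what is new or still open speak of the compounds shown alone.

Compound 1 `Nc1cc(N)c2nc(-c3ccccc3)c(Oc3ccc(Cl)c(Cl)c3)nc2c1` carries a 3,4-dichlorophenoxy group on the shared core. In a functional assay on SW-620 cells (Homo sapiens) for inhibition, read by sulforhodamine B assay, with a stated time of 48 h (a higher number here means a weaker inhibitor of growth, a lower number a stronger inhibitor of growth), compound 1 gives 9770 nM, one of only two numbers shown, and compound 3 `CCOC(=O)[C@H](CCC(=O)O)NC(=O)c1ccc(Sc2nc3cc(N)cc(N)c3nc2-c2ccccc2)cc1` gives 11700 nM, a value within the scatter of that of compound 1. Compound 2 `CCOC(=O)[C@H](CCC(=O)O)NC(=O)c1ccc(CNc2nc3cc(N)cc(N)c3nc2-c2ccccc2)cc1` reaches only a limit of the assay, < 100000 nM. Compound 4 `COc1ccc(Sc2nc3cc(N)cc(N)c3nc2-c2ccccc2)cc1` differs from compound 1 by (4-methoxyphenyl)sulfanyl in place of 3,4-dichlorophenoxy on an aromatic carbon. Within the data shown here, no measured pair covers this change directly; compound 3 shows that a sulfur-linked aryl group at this place gives a number close to that of compound 1. In this assay the expected step is a 1.0-fold higher number from compound 1 to compound 4 (0.01 log units; within the scatter), none beyond the scatter. Compound 4 is estimated at 10000 nM, between 3000 nM and 35000 nM.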

Compound 4, concentration for 50% growth inhibition: 26300 nM
Estimate against measurement, compound 4: 2.6-fold (0.42 log units) below; the range from low to high includes it.
By their numbers in this assay, from the lowest: compounds 1 and 3 (each within the scatter of the next); then compound 4.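

The change from 3,4-dichlorophenoxy to (4-methoxyphenyl)sulfanyl at this position gives a 2.7-fold higher number from compound 1 to compound 4 (0.43 log units; beyond the scatter) in this assay, so a sulfur-linked aryl group here does not by itself hold the number of compound 1. Sulfur-linked compound 3 gives 11700 nM and sulfur-linked compound 4 gives 26300 nM, so these two groups do not share one number. Nothing shown bears on why the number of compound 4 differs from that of compound 1.

This change alters the linking atom and the ring substituents together, and the compounds shown do not separate the two. Going by these compounds, how 4-methoxyphenoxy or an amine on the sulfur-linked ring would read here remains open.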